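Aryl changes on the oxygen: three limits so far

This account rests on a few compounds, and the source may have more. Where it says the series, first, only, none or still open, it means among the compounds named here.

Values in a functional assay on Jurkat cells (Homo sapiens) (a higher number here means a weaker inhibitor, a lower number a stronger inhibitor), each one a limit:
- compound 1 `CC(C)[C@H](NC(=O)COc1cccc2ccccc12)C(=O)N[C@@H](CC(=O)O)C(=O)COc1ccc2ccccc2c1`: > 100000 nM
- compound 2 `CC(C)[C@H](NC(=O)COc1cccc2ccccc12)C(=O)N[C@@H](CC(=O)O)C(=O)COc1ccc(C#N)cc1`: > 100000 nM
- compound 3 `CC(C)[C@H](NC(=O)COc1cccc2ccccc12)C(=O)N[C@@H](CC(=O)O)C(=O)COc1ccc(F)c(F)c1`: > 100000 nM

Compound 3 stands at the limit of > 100000 nM in this assay, at which 3 of the 3 values shown sit, so it has no numerical value. Compound 4 `CC(C)[C@H](NC(=O)COc1cccc2ccccc12)C(=O)N[C@@H](CC(=O)O)C(=O)COc1c(F)c(F)cc(F)c1F` carries 2,3,5,6-tetrafluorophenyl in place of 3,4-difluorophenyl on an oxygen on a saturated carbon. Three measured steps change this same place: a step that the two limits leave unreadable from compound 1 to compound 2, a step that the two limits leave unreadable from compound 1 to compound 3 and a step that the two limits leave unreadable from compound 2 to compound 3. None of them gives a size. A readable step in this assay could only run towards a stronger inhibitor, and another limit remains possible. The expected change is an at least 33-fold lower number from compound 3 to compound 4 (1.52 log units; beyond the scatter). For compound 4 the estimated value is 3000 nM, with an expected range of 100 nM to 100000 nM.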

Compound 4, half-maximal inhibitory concentration: 4500 nM
Beside the measured number, compound 4's estimate is 1.5-fold (0.18 log units) below it; the range from low to high includes it.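

In this assay compound 4 gives the first readable value among these aryl groups, so a change on this oxygen alone is enough to leave the limit (an at least 22-fold lower number from compound 3 to compound 4 (1.34 log units; beyond the scatter)). The same gain appears against 4-cyanophenyl (an at least 22-fold lower number from compound 2 to compound 4 (1.34 log units; beyond the scatter)) and naphthalen-2-yl (an at least 22-fold lower number from compound 1 to compound 4 (1.34 log units; beyond the scatter)), while the steps among compound 1, compound 2 and compound 3 cannot be read. Those three compounds remain limits, not numbers: the limit of > 100000 nM in this assay, at which 3 of the 4 values shown sit.

The compounds shown leave open whether the number of fluorines or their placement on the ring accounts for the gain. As far as these compounds go, whether a pentafluorophenyl group on this oxygen would lower the number further also remains open.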